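The compounds below may be only part of what the source reports. "The series", "measured", "known", "first", "only" and "open" are said of these compounds alone.

In a functional assay on BGC-823 cells (Homo sapiens) for antiproliferative activity, read by MTT assay, tested at 1 uM (on this read-out lower numbers stand for a weaker effect and higher numbers for a stronger effect at the one concentration tested), compound 2 `COc1cc(C2=NN(C(C)=O)C(c3ccccc3C(F)(F)F)O2)cc(OC)c1OC` gives 31.8%, the higher of the two numbers in hand. In this assay compound 1 `COc1ccc(/C=N/NC(=O)c2cc(OC)c(OC)c(OC)c2)c(OC)c1` gives -6.9%, a gap well beyond the usual scatter. Compound 3 `COc1cc(C2=NN(C(C)=O)C(c3ccccc3F)O2)cc(OC)c1OC` differs from compound 2 only by fluoro in place of trifluoromethyl on an aromatic carbon. For the measured compounds named here, no pair of measured compounds shows what such a swap does, so the expected step in this assay is small, pointing slightly downward and possibly staying within the scatter. Compound 3 is therefore estimated to give 25%, in a range from 5% to 45%. That estimate implies a step of a number 6.8 percentage points lower from compound 2 to compound 3 (within the scatter).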

Compound 3, a percentage reported as inhibition, at one concentration (the size of the read-out at that concentration, not a potency): 29.6%
Estimate against measurement, compound 3: 4.6 percentage points below, within the range that was stated.
By their numbers in this assay, from the lowest: compound 1; then compounds 3 and 2 (each within the scatter of the next).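

The swap of trifluoromethyl for fluoro at this place, on an aromatic carbon ortho to a large group, gives a step of a number 2.2 percentage points lower from compound 2 to compound 3 (within the scatter) in this assay. This first measured pair shows that the much smaller group leaves the read-out unchanged within the scatter, so this position does not depend on keeping trifluoromethyl. Nothing available explains why the two groups read alike. Still open, going by these compounds, is what an amine or a carboxylic acid would do at this carbon. A single concentration also cannot show whether compound 2 and compound 3 match in potency.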